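The compounds below may be only part of what the source reports. "The series", "measured", "known", "first", "only" and "open" are said of these compounds alone.

The measured compounds, with their numbers in a functional assay on PC-3 cells (Homo sapiens) for antiproliferative activity, read by MTT assay, with a stated time of 72 h; on this read-out higher numbers stand for weaker inhibition and lower numbers for stronger inhibition:
compound 1 `O=C(N/N=C/c1ccc(F)cc1)Nc1ccc(Oc2ccnc3[nH]ccc23)c(F)c1` gives 2330 nM
compound 2 `O=C(N/N=C/c1ccc([N+](=O)[O-])cc1)Nc1ccc(Oc2ccnc3[nH]ccc23)c(F)c1` gives 150 nM
compound 3 `COc1ccc(/C=N/NC(=O)Nc2ccc(Oc3ccnc4[nH]ccc34)c(F)c2)cc1` gives 6730 nM

Among these three, compound 1 holds the second highest number: compound 3 sits nearest to it, at a 2.9-fold higher number from compound 1 to compound 3 (0.46 log units; beyond the scatter), while compound 2 lies furthest, at a 16-fold lower number from compound 1 to compound 2 (1.19 log units; beyond the scatter). Compound 4 `O=C(N/N=C/c1ccc(O)cc1O)Nc1ccc(Oc2ccnc3[nH]ccc23)c(F)c1` differs from compound 1 in one place: 2,4-dihydroxyphenyl in place of 4-fluorophenyl on a carbon with a double bond to nitrogen.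

For the measured compounds named here, two measured steps touch the same position. The nitro change gave a 16-fold lower number from compound 1 to compound 2 (1.19 log units; beyond the scatter); the methoxy change gave a 2.9-fold higher number from compound 1 to compound 3 (0.46 log units; beyond the scatter). Going by the values given here, no measured step introduces a hydroxyl, nor two groups on that ring at once, so the comparison is indirect. The oxygen-bearing methoxy is the closer precedent, and it moved the number upward, so a modest upward step or none beyond the scatter is expected for compound 4, with wide uncertainty. The estimated step is a 1.5-fold higher number from compound 1 to compound 4 (0.18 log units; within the scatter). Compound 4 is therefore expected to give about 3500 nM in this assay, within a range from 900 nM to 14000 nM.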

Compound 4, half-maximal inhibitory concentration: 13000 nM
Beside the measured number, compound 4's estimate is 3.7-fold (0.57 log units) below it; the measured number falls inside the stated range.
By their numbers in this assay, from the lowest: compound 2; then compound 1; then compounds 3 and 4 (each within the scatter of the next).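

In this assay, 2,4-dihydroxyphenyl in place of 4-fluorophenyl on the carbon with a double bond to nitrogen gave a 5.6-fold higher number from compound 1 to compound 4 (0.75 log units; beyond the scatter) and so showed that the two hydroxyls on this ring, like the methoxy of compound 3, go with a higher number than the fluoro of compound 1. Set against 4-methoxyphenyl, the same ring gave a 1.9-fold higher number from compound 3 to compound 4 (0.29 log units; within the scatter) and these two compounds cannot be told apart, whereas against 4-nitrophenyl it gave an 87-fold higher number from compound 2 to compound 4 (1.94 log units; beyond the scatter) and this widens the spread seen at this one position, with compound 2 alone at the low end. No measurement at hand accounts for these steps.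

Going by these compounds, whether a nitrile or trifluoromethyl would share the low number of the nitro compound remains open. So does how a ring carrying one hydroxyl or an amine would read here.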